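This account rests on a few compounds, and the source may have more. Where it says the series, first, only, none or still open, it means among the compounds named here.

Compound 1 `CN(C)C(=O)c1cc2cnc(Nc3ccc(S(=O)(=O)NCCCN=C=S)cc3)nc2n1C1CCCC1` is one of three compounds tested in a functional assay on NCI-H1299 cells (Homo sapiens) for inhibition, read by CCK-8 assay, with a stated time of 72 h, tested at 10 uM; a higher number here means a stronger effect of the compound at the concentration tested, a lower number a weaker effect. In this assay compound 1 gives 72.8%, the second highest of the three numbers. Compound 2 `CN(C)C(=O)c1cc2cnc(Nc3ccc(S(=O)(=O)NCCCCN=C=S)cc3)nc2n1C1CCCC1` gives 72.7%, and compound 3 `CN(C)C(=O)c1cc2cnc(Nc3ccc(S(=O)(=O)NCCCCCCCN=C=S)cc3)nc2n1C1CCCC1` gives 83%. Lengthening the chain that ends in the isothiocyanate by one carbon gives a number 0.1 percentage points lower from compound 1 to compound 2 (within the scatter), so these two values are indistinguishable, while lengthening it by four carbons gives a number 10.2 percentage points higher from compound 1 to compound 3 (beyond the scatter), a modest gain.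

Compound 4 `CN(C)C(=O)c1cc2cnc(Nc3ccc(C(=O)NCCCN=C=S)cc3)nc2n1C1CCCC1` keeps the same chain end as compound 1 and changes something else: a group of 9 heavy atoms (5 carbon, 2 nitrogen, 1 oxygen, 1 sulfur; no ring) in place of a group of 10 heavy atoms (4 carbon, 2 nitrogen, 2 oxygen, 2 sulfur; no ring), on an aromatic carbon. The group that leaves sits on an aromatic carbon of a six-membered aromatic ring of carbon only, para to a large group, and the new group takes its place there. None of the three measured steps touches this position; all of them alter only the length of the chain. There is therefore no measured guide to this change, and the sensible expectation is a step of no clear size in either direction, with the estimate centred near the value of compound 1 and a wide range. Compound 4 is expected to give about 70%, between 52% and 84%, which means an expected a number 2.8 percentage points lower from compound 1 to compound 4 (within the scatter).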

Compound 4, a percentage reported as inhibition, at one concentration (the size of the read-out at that concentration, not a potency): 91.2%
Estimate against measurement, compound 4: 21.2 percentage points below, outside the stated range (above it).
By their numbers in this assay, from the lowest: compounds 2 and 1 (each within the scatter of the next); then compounds 3 and 4 (each within the scatter of the next).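

On an aromatic carbon of a six-membered aromatic ring of carbon only, para to a large group, the link to the chain turns out to matter: in this assay, with the chain ending in the isothiocyanate left as it is, exchanging the sulfonamide link for an amide link gives a number 18.4 percentage points higher from compound 1 to compound 4 (beyond the scatter). Starting from the chain that is one carbon longer, the comparison points the same way, with a number 18.5 percentage points higher from compound 2 to compound 4 (beyond the scatter), although that step changes the chain length as well as the link. Chain length is therefore no longer the only place shown to shift this read-out beyond the scatter, but nothing available explains why this exchange does so.

From the compounds shown here alone, whether the amide link and the longer chain of compound 3 can be combined to any benefit remains open, since every amide result here rests on compound 4 alone. Going by these compounds, it is also open how a urea or a reversed amide would behave in this place, and whether the gain would survive replacing the isothiocyanate with an acrylamide.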